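A few compounds are considered here, and "the series" means these few. Any claim that something is new, unique, unknown or untested is made for them only; others in the source may bear on it.

Series notes, half-life in mouse liver microsomes.

Compound 1 `N#Cc1ncc(N2C(=O)C3(CCC3)N(c3ccc(OC4CCNCC4)nc3)C2=S)cc1C(F)(F)F` is the reference point. In an ADME assay on microsomes from liver (Mus musculus, strain CD1) for metabolic stability (a higher number here means that the compound lasts longer, a lower number that the compound disappears faster), compound 1 gives > 3 h, which is a limit of the assay and not a number. For the measured compounds named here, that limit, (the limit of > 3 h in this assay, at which 1 of the 3 values shown sits), is the only information on where compound 1 stands. Going by the values given here, compound 3 `CN1CCC(Oc2ccc(N3C(=S)N(c4cnc(C#N)c(C(F)(F)F)c4)C(=O)C34CCC4)cn2)CC1` gives 2.88 h in this assay, and the step of an at least 1.0-fold lower number from compound 1 to compound 3 (0.01 log units; that floor lies within the scatter) is the single measured change in the set; compound 2 `COc1cc(N2C(=O)C3(CCC3)N(c3ccc(OC4CCN(C)CC4)cc3)C2=S)cnc1C#N` gives 1.9 h in this assay.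

Compound 4 `N#Cc1ncc(N2C(=O)C3(CCC3)N(c3ccc(OC4CCNCC4)nc3)C2=S)cc1Cl` differs from compound 1 as follows: chloro in place of trifluoromethyl on an aromatic carbon. Among the compounds with values here, no measured step touches the trifluoromethyl position, and the one measured step stays within the scatter, so no direction is expected beyond the scatter; the step of an at least 1.1-fold lower number from compound 1 to compound 4 (0.06 log units; that floor lies within the scatter) is an estimate only. Compound 4 is accordingly expected at 2.6 h in this assay, within 1.2 h to 5.5 h.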

Compound 4, half-life: > 3 h
Compound 4 ended at the assay's limit; the forecaster's own chance of this, stated with the estimate: 40%; middle value at least 1.1-fold (0.06 log units) away from the limit.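

No step can be read from compound 1 to compound 4, as both values are limits of this assay and not numbers: the limit of > 3 h in this assay, at which 2 of the 4 values shown sit.

From the compounds shown here alone, whether chloro in place of trifluoromethyl changes the half-life at all, and in which direction, stays open.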